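The source may report more compounds than this note shows. Statements on the series, on what has been measured and on what is new or still open speak of the compounds shown alone.

Measured compounds:
- compound 1 `COc1ccccc1C[C@H]1COC(=O)[C@@H]1Cc1ccc(Cl)c(Cl)c1`: 24000 nM
- compound 2 `O=C1OC[C@H](Cc2cccc(O)c2)[C@H]1Cc1ccc(Cl)c(Cl)c1`: "not determined" (no result reported)

In a functional assay on HeLa cells (Homo sapiens) for cytotoxicity, read by WST assay, with a stated time of 48 h (on this read-out lower numbers stand for an effect already at smaller amounts and higher numbers for an effect only at larger amounts of compound), compound 1 gives 24000 nM. For compound 2 no number exists in this assay, so it stands nowhere on the scale shown. Compound 3 `O=C1OC[C@H](Cc2cccc(F)c2)[C@H]1Cc1ccc(Cl)c(Cl)c1` differs from compound 2 by a single change (fluoro in place of hydroxy on an aromatic carbon). Within the data shown here, with no value for compound 2, no step can be expected in either direction beyond the scatter; the only anchor is compound 1. Because compound 1 gives 24000 nM, compound 3 is estimated at 20000 nM, within a range of 5000 nM to 80000 nM.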

Compound 3, half-maximal effective concentration: 20000 nM
Compound 3: the middle estimate sits on the measured number at the digits printed; low and high end bracket the measured number.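

In this assay, exchanging the aromatic group on the chain gives a 1.2-fold lower number from compound 1 to compound 3 (0.08 log units; within the scatter), so 2-methoxyphenyl and 3-fluorophenyl cannot be told apart at this position. Compound 2 has no number, so the change from 3-hydroxyphenyl to 3-fluorophenyl cannot be read. Nothing shown here offers a cause for this result.

Open, from the compounds shown here alone, is how an amine or a carboxylic acid in place of the fluoro would read on this scale, and whether any change at this position moves the number beyond the usual scatter.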